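The compounds below may be only part of what the source reports. "The series", "measured", "known", "first", "only" and "open" are said of these compounds alone.

Among the compounds with values here, compound 2 `CCCCc1sc(-c2ccc(OCCCN3CCCCC3)cc2)nc1-c1ccc(Oc2ccc(Cl)cc2)cc1` shows the higher of the two numbers so far in an assay on isolated protein for antagonist activity at advanced glycosylation end product-specific receptor (Homo sapiens), read by ELISA, with a stated time of 60 min, tested at 10 uM; on this read-out lower numbers stand for less inhibition and higher numbers for more inhibition at the one concentration tested (going by the name of the read-out): compound 2 gives 59.2%, while compound 1 `CCCCc1sc(-c2ccc(OCC3CCCN(CC)C3)cc2)nc1-c1ccc(Oc2ccc(Cl)cc2)cc1` gives 58%, a gap that stays within the scatter. Within the data shown here, the one step already seen at the amine end of the chain, a number 1.2 percentage points higher from compound 1 to compound 2 (within the scatter), exchanged one cyclic amine for another without a shift beyond the scatter. Compound 3 `CCCCc1sc(-c2ccc(OCCCN(CC)CC)cc2)nc1-c1ccc(Oc2ccc(Cl)cc2)cc1` carries the change (diethylamino in place of piperidin-1-yl on a saturated chain carbon, three bonds along the chain from an oxygen on an aromatic ring). Among the measured compounds shown here, no measured step replaces a ring amine with an open-chain one, so the step from compound 1 to compound 2 is the closest guide, and it was small. A change of the same order, that is none beyond the scatter, is therefore expected for a number 2.2 percentage points lower from compound 2 to compound 3 (within the scatter) in this assay. For compound 3 the estimate in this assay is accordingly 57%, expected to lie between 42% and 70%.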

Compound 3, a percentage reported as inhibition, at one concentration (the size of the read-out at that concentration, not a potency): 58.9%
Compound 3: middle estimate off by 1.9 percentage points, on the low side; low and high end bracket the measured number.
By their numbers in this assay, from the lowest: compounds 1, 3 and 2 (each within the scatter of the next).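

Putting diethylamino in place of piperidin-1-yl, on a saturated chain carbon three bonds along the chain from an oxygen on an aromatic ring, gives in this assay a number 0.3 percentage points lower from compound 2 to compound 3 (within the scatter) and thus shows that at this place the amine need not sit in a ring to hold this level of inhibition at the one concentration tested. The open-chain compound also matches the 1-ethylpiperidin-3-yl compound, with a number 0.9 percentage points higher from compound 1 to compound 3 (within the scatter) in this assay so that the three amine ends shown cannot be told apart in this read-out. Nothing at hand gives a reason for this flat result.

All three compounds keep a fully substituted amine, which leaves open whether a primary amine, a morpholine ring or a carboxylic acid in its place would hold the number. On these data alone, a longer chain carrying the amine also remains open.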